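Ester in place of the thiophen-2-yl ketone: cytotoxicity outlook

This account rests on a few compounds, and the source may have more. Where it says the series, first, only, none or still open, it means among the compounds named here.

Measured so far:
compound 1 `CC(=O)/C(=C/c1c(-c2ccccc2)[nH]c2ccccc12)C(=O)c1ccccc1`: > 100000 nM
compound 2 `N#C/C(=C\c1c(-c2ccccc2)[nH]c2ccccc12)C(=O)c1cccs1`: 45000 nM
compound 3 `COc1ccc2[nH]c(-c3ccccc3)c(/C=C(\C#N)S(=O)(=O)c3ccccc3)c2c1`: 11000 nM

In an ADME assay on CRL-7065 cells (Homo sapiens) for cytotoxicity, read by MTT assay, with a stated time of 96 h (on this read-out higher numbers stand for an effect only at larger amounts of compound and lower numbers for an effect already at smaller amounts), the read-out for compound 1 is a limit, not a number: the limit of > 100000 nM in this assay, at which 1 of the 3 values shown sits. Among the two numbers, compound 2 gives 45000 nM, the higher one, while compound 3 at 11000 nM sits lower by a gap beyond the scatter. Compound 4 `COCCOC(=O)/C(C#N)=C/c1c(-c2ccccc2)[nH]c2ccccc12` differs from compound 2 by 2-methoxyethoxy in place of thiophen-2-yl on a carbonyl carbon. Going by the values given here, no measured pair shows this kind of change, so there is nothing to lean on beyond the spread of the three values. The step of a 1.3-fold lower number from compound 2 to compound 4 (0.11 log units; within the scatter) is expected to fall within the scatter, with a lower number somewhat more likely than a higher one. Compound 4 is estimated at 35000 nM, between 9000 nM and 100000 nM.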

Compound 4, half-maximal effective concentration: 76000 nM
For compound 4 the middle estimate is 2.2-fold (0.34 log units) below the measured one, within the range that was stated.
By their numbers in this assay, from the lowest: compound 3; then compounds 2 and 4 (each within the scatter of the next). At a limit, above all of these: compound 1.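

The first step read at this place comes from this assay: a 1.7-fold higher number from compound 2 to compound 4 (0.23 log units; within the scatter). On this carbonyl carbon, an open 2-methoxyethoxy chain with no ring and thiophen-2-yl therefore cannot be told apart, so the aromatic ring is not required for a numeric read-out. Nothing measured here gives a cause for this step.

Open, from the compounds shown here alone, is whether a carboxylic acid, an amine-derived amide or a longer ether chain on this carbonyl carbon would also stay within the scatter of compound 2. A single pair cannot show whether the same holds on other cores.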